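Series notes: bromo in place of fluoro on the aryl ring

A few compounds are considered here, and "the series" means these few. Any claim that something is new, unique, unknown or untested is made for them only; others in the source may bear on it.

Measured so far in a functional assay on MDA-MB-231 cells (Homo sapiens), read by fluorescence and BrdU incorporation, with a stated time of 48 h, tested at 10 uM; a higher number here means a weaker effect of the compound at the concentration tested, a lower number a stronger effect:
compound 1 `COc1cc(OC)c(C(=O)/C=C/c2ccccc2SC)c(OC)c1`, 48%
compound 2 `COc1cccc(/C=C/C(=O)c2c(OC)cc(OC)cc2OC)c1`, 43%
compound 3 `COc1cc(OC)c(C(=O)/C=C/c2ccc(F)cc2)c(OC)c1`, 43%

Compound 3 stands level with compound 2 at the digits shown, the two together the lowest of the three numbers; compound 1 is the furthest, see a number 5 percentage points lower from compound 1 to compound 3 (within the scatter). Compound 4 `COc1cc(OC)c(C(=O)/C=C/c2ccc(Br)cc2)c(OC)c1` is not yet measured. The change from compound 3 is bromo in place of fluoro on an aromatic carbon. The measured steps all swap the group on the aryl ring: no change at the digits printed from compound 2 to compound 3 (within the scatter), a number 5 percentage points lower from compound 1 to compound 2 (within the scatter), a number 5 percentage points lower from compound 1 to compound 3 (within the scatter), every one within the scatter. Within the data shown here, no halogen-for-halogen step has been measured. A step within the scatter is therefore expected, a number 2 percentage points lower from compound 3 to compound 4 (within the scatter). Compound 4 is estimated at 41%, range 29% to 53%.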

Compound 4, a percentage reported as activity, at one concentration (the size of the read-out at that concentration, not a potency): 42%
Compound 4: the middle estimate sits 1 percentage points below what was measured; low and high end bracket the measured number.
By their numbers in this assay, from the lowest: compounds 4, 2, 3 and 1 (each within the scatter of the next).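

In this assay, among these compounds, the first halogen-for-halogen step at this position, para to a large group, gives a number 1 percentage points lower from compound 3 to compound 4 (within the scatter), so the change from 4-fluorophenyl to 4-bromophenyl does not separate the two compounds. The other new steps read alike, with a number 1 percentage points lower from compound 2 to compound 4 (within the scatter) and a number 6 percentage points lower from compound 1 to compound 4 (within the scatter), so no aryl group shown stands apart. No measured evidence is available to explain this flat read-out.

As far as these compounds go, whether an amine or a carboxylic acid on this aromatic carbon would give a step beyond the scatter remains open. Also open, from the compounds shown here alone, is how the read-out responds to changes in the shared core, which all four compounds carry unchanged.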